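The compounds below may be only part of what the source reports. "The series", "measured", "known", "first", "only" and "open" are said of these compounds alone.

Measured compounds and their numbers in a functional assay on the whole organism for activation, with Mus musculus as the target; a higher number here means that more compound is needed for the effect, a lower number that less compound is needed:
compound 1, `CCc1nc(N)c2nc(O)n(Cc3ccccc3)c2n1`, gives 3 mg/kg;
compound 2, `CCCNc1nc(N)c2nc(O)n(Cc3ccccc3)c2n1`, gives 1 mg/kg;
compound 3, `CCCC[S+]([O-])c1nc(N)c2nc(O)n(Cc3ccccc3)c2n1`, gives 1 mg/kg.

On these numbers compound 3 stands level with compound 2, the two together giving the lowest numbers of the three, while compound 1 needs more: a 3.0-fold lower number from compound 1 to compound 3 (0.48 log units; beyond the scatter). Compound 4, `CCCCSc1nc(N)c2nc(O)n(Cc3ccccc3)c2n1`, differs from compound 3 in one place: a group of 5 heavy atoms (4 carbon, 1 sulfur; no ring) in place of a group of 6 heavy atoms (4 carbon, 1 oxygen, 1 sulfur; no ring), on an aromatic carbon. For the measured compounds named here, no measured step swaps the leaving group for the entering one. The steps that touch the same carbon are a 3.0-fold lower number from compound 1 to compound 2 (0.48 log units; beyond the scatter), a 3.0-fold lower number from compound 1 to compound 3 (0.48 log units; beyond the scatter) and no change at the digits printed from compound 2 to compound 3 (within the scatter); they show that quite different groups at this position give similar or lower numbers, so a change beyond the scatter in this assay is not expected. Compound 4 is expected to show no change at the digits printed from compound 3 to compound 4 (within the scatter). The estimate for compound 4 is 1 mg/kg, in a range from 0.3 mg/kg to 3 mg/kg.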

Compound 4, minimum effective dose: 0.3 mg/kg
Estimate against measurement, compound 4: 3.3-fold (0.52 log units) above; the range from low to high includes it.
By their numbers in this assay, from the lowest: compound 4; then compounds 2 and 3 (each within the scatter of the next); then compound 1.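

Removing the oxygen from the sulfur of the butyl chain matters at this carbon: this assay shows a 3.3-fold lower number from compound 3 to compound 4 (0.52 log units; beyond the scatter). Butylsulfanyl also compares well with the other groups here, giving a 3.3-fold lower number from compound 2 to compound 4 (0.52 log units; beyond the scatter) and a 10-fold lower number from compound 1 to compound 4 (1.00 log units; beyond the scatter), so compound 4 has the lowest number of the four. Nothing shown gives a reason for these differences. From the compounds shown here alone, whether a shorter or longer chain on the sulfur, such as methylsulfanyl or hexylsulfanyl, would lower the number further remains open. So does whether butoxy, with oxygen in place of the sulfur, would match compound 4.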